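Chain methyl on compound 3: expected effect on solubility

The source may report more compounds than this note shows. Statements on the series, on what has been measured and on what is new or still open speak of the compounds shown alone.

In a physicochemical assay for solubility, read by HPLC, in phosphate buffer, with a stated time of 24 h, at pH 7.4, tested at 100 uM (on this read-out higher numbers stand for higher solubility and lower numbers for lower solubility), compound 3 `COc1ccc(Nc2c(NCCCCCC(=O)NO)c(=O)c2=O)cc1` gives 3300000 nM, the lowest of three numbers, under compound 2 `Cc1ccc(Nc2c(NCCCCCC(=O)NO)c(=O)c2=O)cc1` at 8100000 nM and compound 1 `O=C(CCCCCNc1c(NCc2ccccc2)c(=O)c1=O)NO` at 75000000 nM. Compound 4 `COc1ccc(Nc2c(NC(C)CCCCC(=O)NO)c(=O)c2=O)cc1` has methyl in place of hydrogen on a saturated chain carbon bound to a nitrogen on an aromatic ring and a saturated chain carbon. For the measured compounds named here, no measured step touches this chain. Going by the values given here, the only steps available lie at the other nitrogen: a 9.3-fold lower number from compound 1 to compound 2 (0.97 log units; beyond the scatter), a 23-fold lower number from compound 1 to compound 3 (1.36 log units; beyond the scatter) and a 2.5-fold lower number from compound 2 to compound 3 (0.39 log units; beyond the scatter). The last, a single-group swap, is the closest guide and was modest, so no step beyond the scatter is expected in this assay, with a slight lean downward. The estimate means a 1.2-fold lower number from compound 3 to compound 4 (0.07 log units; within the scatter). For compound 4 the expected value is 2800000 nM, with an estimated range of 1100000 nM to 7000000 nM.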

Compound 4, solubility: 85000000 nM
For compound 4 the middle estimate is 30-fold (1.48 log units) below the measured one; measured number above the stated range.
By their numbers in this assay, from the lowest: compound 3; then compound 2; then compounds 1 and 4 (each within the scatter of the next).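

In this assay the saturated chain carbon bound to a nitrogen on an aromatic ring and a saturated chain carbon proves far from neutral: methyl in place of hydrogen, only one added carbon, gives a large step (a 26-fold higher number from compound 3 to compound 4 (1.41 log units; beyond the scatter)). Until now, large steps had appeared only at the other nitrogen, so this chain position is a second site of strong change in the series. Nothing at hand accounts for the rise.

Open, as far as these compounds go, is whether ethyl or a hydroxymethyl group at this carbon would give a similar step. Also open, from the compounds shown here alone, is whether the same methyl would act alike on the cores of compound 1 and compound 2.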